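From oxan-4-yl to phenyl in a small series

The source may hold more compounds than are shown below. What is called first, only, known or untested is meant among the compounds shown, and "the series" means these compounds.

In a functional assay on HT-29 cells (Homo sapiens) for inhibition, read by luminescence and CellTiter-Glo, with a stated time of 24 h (a lower number here means that less compound is needed, a higher number that more compound is needed for the effect), compound 1 `CC(C)n1nc(C(=O)N[C@H]2COc3ccccc3N(C)C2=S)nc1Cc1ccccc1` gives 360 nM and compound 2 `COCCn1nc(C(=O)N[C@H]2COc3ccccc3N(C)C2=S)nc1Cc1ccccc1` gives 566 nM, which is a 1.6-fold higher number from compound 1 to compound 2 (0.20 log units; within the scatter). Compound 3 `CN1C(=S)[C@@H](NC(=O)c2nc(Cc3ccccc3)n(CC3CCOCC3)n2)COc2ccccc21` has the highest number of the three at 6310 nM. Compound 4 `CN1C(=S)[C@@H](NC(=O)c2nc(Cc3ccccc3)n(Cc3ccccc3)n2)COc2ccccc21` differs from compound 3 by one change: phenyl in place of oxan-4-yl on a saturated chain carbon bound to an aromatic nitrogen. In words, this is phenyl in place of oxan-4-yl on a saturated chain carbon bound to an aromatic nitrogen, so benzyl replaces (oxan-4-yl)methyl. Within the data shown here, no measured step makes this exact swap. The nearest measured steps are large, an 18-fold higher number from compound 1 to compound 3 (1.24 log units; beyond the scatter) and an 11-fold higher number from compound 2 to compound 3 (1.05 log units; beyond the scatter), so a partial return toward lower numbers is expected. The estimated step is a 3.2-fold lower number from compound 3 to compound 4 (0.50 log units; beyond the scatter). Compound 4 is expected at 2000 nM, within an estimated range of 350 nM to 10000 nM.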

Compound 4, half-maximal effective concentration: 414 nM
The estimate for compound 4 lay 4.8-fold (0.68 log units) above the measured number; measured number inside the range.
By their numbers in this assay, from the lowest: compounds 1, 4 and 2 (each within the scatter of the next); then compound 3.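

Phenyl in place of oxan-4-yl on a saturated chain carbon bound to an aromatic nitrogen gives a large change in this assay (a 15-fold lower number from compound 3 to compound 4 (1.18 log units; beyond the scatter)), so two six-membered rings of equal heavy-atom count are not interchangeable here. Benzyl cannot be told apart from isopropyl (a 1.2-fold higher number from compound 1 to compound 4 (0.06 log units; within the scatter)) or from 2-methoxyethyl (a 1.4-fold lower number from compound 2 to compound 4 (0.14 log units; within the scatter)), which leaves (oxan-4-yl)methyl as the only one of these four groups that stands apart. Nothing shown here explains the gap between oxan-4-yl and phenyl. Still open, on these data alone, is whether an amine or a carboxylic acid on the benzyl group would keep this number, and what a longer chain would do.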